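Isobutyl on the bromo analogue: expected antiproliferative gain

This account rests on a few compounds, and the source may have more. Where it says the series, first, only, none or still open, it means among the compounds named here.

The shared core is that of compound 1 `Cc1ccc(S(=O)(=O)N2CCC(Cl)CC2)cc1`. In a functional assay on SW1573 cells (Homo sapiens) for antiproliferative activity, read by sulforhodamine B assay, with a stated time of 48 h (a lower number here means a stronger inhibitor of growth, a higher number a weaker inhibitor of growth), compound 1 sits at the limit of the assay, > 100000 nM. Compound 2 `Cc1ccc(S(=O)(=O)N2CC[C@@H](Cl)C[C@@H]2CC(C)C)cc1` adds an isobutyl group on a saturated ring carbon, and in this assay compound 2 gives 19000 nM; this is an at least 5.2-fold lower number from compound 1 to compound 2 (0.72 log units; beyond the scatter). Compound 3 `Cc1ccc(S(=O)(=O)N2CCC(Br)CC2)cc1` carries bromo instead of chloro. In this assay compound 3 also reaches only the limit, > 100000 nM. As a result the exchange of halogen is a step that the two limits leave unreadable from compound 1 to compound 3, and compound 3 is placed only by the limit of > 100000 nM in this assay, at which 2 of the 3 values shown sit.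

Compound 4 `Cc1ccc(S(=O)(=O)N2CC[C@@H](Br)C[C@@H]2CC(C)C)cc1` repeats the change of compound 2 on the bromo core: isobutyl in place of hydrogen on a saturated ring carbon. Among the compounds with values here, the single measured step that bears on this is the isobutyl addition on the chloro core, which lowered the number beyond the scatter. A similar lowering is expected here, though compound 3 starts from a limit, so the size is uncertain.

Compound 4 is expected to give 20000 nM in this assay, between 6000 nM and 70000 nM, which corresponds to an estimated at least 5.0-fold lower number from compound 3 to compound 4 (0.69 log units; beyond the scatter).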

Compound 4, concentration for 50% growth inhibition: 22000 nM
For compound 4 the middle estimate is 1.1-fold (0.04 log units) below the measured one; the measured number falls inside the stated range.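

In this assay, isobutyl in place of hydrogen on a saturated ring carbon next to the ring nitrogen also lowers the number on the bromo core (an at least 4.5-fold lower number from compound 3 to compound 4 (0.65 log units; beyond the scatter)), so the gain now appears on two cores: the same change on two cores in this assay, an at least 5.2-fold lower number (0.72 log units; beyond the scatter) from compound 1 to compound 2 and an at least 4.5-fold lower number (0.65 log units; beyond the scatter) from compound 3 to compound 4; the limit leaves it open whether they differ. The halogen exchange, unreadable between the two compounds without isobutyl, can be read with isobutyl present. There, bromo and chloro lie within the scatter of each other (a 1.2-fold higher number from compound 2 to compound 4 (0.06 log units; within the scatter)), so in this pair the number does not depend on which of the two halogens is present.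

On these data alone, whether a methyl group or a longer chain such as hexyl at the same ring carbon would lower the number further remains open. As far as these compounds go, it is also open whether an amine or a carboxylic acid would be tolerated there, or whether a hydroxyl group could replace the halogen.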